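A few compounds are considered here, and "the series" means these few. Any claim that something is new, unique, unknown or untested is made for them only; others in the source may bear on it.

Measured so far in an ADME assay on the whole organism with Oryza sativa as the target, tested at 1 uM; on this read-out lower numbers stand for a stronger effect and higher numbers for a weaker effect at the one concentration tested:

compound 1 `Cc1ccccc1NC(=O)N[C@@H](C)c1ccccc1`: 99%
compound 2 `C[C@H](NC(=O)Nc1ccc(F)cc1)c1ccccc1`: 97%
compound 3 `Cc1cc(F)ccc1NC(=O)N[C@H](C)c1ccccc1`: 100%

In this assay compound 3 gives the highest of the three numbers. Its nearest neighbour is compound 1, a little lower and within the scatter, and the furthest is compound 2, also lower and still within the scatter, so the three compounds are not separated by this read-out.

The next compound is compound 4 `Cc1cc(F)ccc1NC(=O)N[C@@H](C)c1ccccc1`, not yet measured in this assay. (the two compounds have the same atoms and bonds and differ only in configuration as drawn: 1 of 1 stereo elements differ; a stereocentre at a saturated chain carbon is drawn R in compound 3 and S in compound 4). For the measured compounds named here, no pair of measured compounds differs in one place, so no measured step size is on record. For a change in configuration alone at a single saturated chain carbon, with all three measured compounds sitting together near the top of the scale, no step beyond the scatter is expected in this assay, in either direction.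

Compound 4 is therefore expected to give about 99% in this assay, within 93% to 100%. That estimate means a step of a number 1 percentage points lower from compound 3 to compound 4 (within the scatter), which is no change beyond the scatter.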

Compound 4, a percentage reported as activity, at one concentration (the size of the read-out at that concentration, not a potency): 98%
Estimate against measurement, compound 4: 1 percentage points above; measured number inside the range.
By their numbers in this assay, from the lowest: compounds 2, 4, 1 and 3 (each within the scatter of the next).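

In this assay, reversing the stereocentre at the saturated chain carbon gives a number 2 percentage points lower from compound 3 to compound 4 (within the scatter), so this read-out does not separate the two configurations. Methyl in place of hydrogen on an aromatic carbon gives a number 1 percentage points higher from compound 2 to compound 4 (within the scatter), and fluoro in place of hydrogen on an aromatic carbon gives a number 1 percentage points lower from compound 1 to compound 4 (within the scatter), so neither replacement shows an effect beyond the scatter either. The stereocentre comparison isolates that single feature: the fact that compounds 3 and 4 differ only in the configuration as drawn.

From the compounds shown here alone, whether any structural change moves this read-out beyond the scatter remains open. A carboxylic acid or an amine in place of the fluoro, or a longer chain at the stereocentre, would test this.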